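Three Measured Analogues and One Awaiting Its Number

The source may hold more compounds than are shown below. What is called first, only, known or untested is meant among the compounds shown, and "the series" means these compounds.

Measured so far:
compound 1 `CCCCOC(=O)NS(=O)(=O)c1sc(CC(C)C)cc1-c1ccc(Cn2ncnn2)cc1`: 16 nM
compound 2 `CCCCOC(=O)NS(=O)(=O)c1sc(CC(C)C)cc1-c1ccc(CN2CCN(C)C2=O)cc1`: 16.5 nM
compound 3 `CCCCOC(=O)NS(=O)(=O)c1sc(CC(C)C)cc1-c1ccc(C(=O)c2ncco2)cc1`: 13.8 nM

All three share the same core and differ only in the group attached to the far aromatic ring. In an assay on membranes from uterus for displacement of a labelled ligand from Angiotensin type II receptor (Sus scrofa), with a stated time of 1.5 h (on this read-out lower numbers stand for stronger inhibition and higher numbers for weaker inhibition), compound 3 gives 13.8 nM, the lowest of the three numbers, but its step of a 1.2-fold lower number from compound 1 to compound 3 (0.06 log units; within the scatter) and its step of a 1.2-fold lower number from compound 2 to compound 3 (0.08 log units; within the scatter) both lie within the scatter, as does a 1.0-fold higher number from compound 1 to compound 2 (0.01 log units; within the scatter), so none of the three can be called the strongest.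

Compound 4 `CCCCOC(=O)NS(=O)(=O)c1sc(CC(C)C)cc1-c1ccc(Cc2nnc(C(F)(F)F)o2)cc1` is the next variation: a group of 10 heavy atoms (4 carbon, 2 nitrogen, 1 oxygen, 3 fluorine; one five-membered aromatic ring with 3 hetero atoms) in place of a group of 7 heavy atoms (4 carbon, 1 nitrogen, 2 oxygen; one five-membered aromatic ring with 2 hetero atoms), on an aromatic carbon. Every change of this group so far has left the number essentially unmoved, so the same is expected here: a step of a 1.1-fold higher number from compound 3 to compound 4 (0.04 log units; within the scatter) that stays within the scatter. Compound 4 is therefore estimated at 15 nM in this assay, with a range from 6 nM to 40 nM.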

Compound 4, inhibition constant: 328 nM
For compound 4 the middle estimate is 22-fold (1.34 log units) below the measured one, outside the stated range (above it).
By their numbers in this assay, from the lowest: compounds 3, 1 and 2 (each within the scatter of the next); then compound 4.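

In this assay this position proves not to be indifferent to what sits on it: the 5-(trifluoromethyl)-1,3,4-oxadiazol-2-yl group gives a large step against each earlier group (a 21-fold higher number from compound 1 to compound 4 (1.31 log units; beyond the scatter)) (a 20-fold higher number from compound 2 to compound 4 (1.30 log units; beyond the scatter)) (a 24-fold higher number from compound 3 to compound 4 (1.38 log units; beyond the scatter)). Compound 1, compound 2 and compound 4 all keep the saturated chain carbon bound to the aromatic carbon, so the group on that carbon alone can move the number far, although the two earlier groups there gave no hint of this. Nothing available here explains the jump.

As far as these compounds go, what a methyl or a plain hydrogen in place of the trifluoromethyl would do stays open, so the ring and the trifluoromethyl cannot yet be told apart. Also open, from the compounds shown here alone, is how an amine or a carboxylic acid on the same chain carbon would read.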